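The source may hold more compounds than are shown below. What is called first, only, known or untested is meant among the compounds shown, and "the series" means these compounds.

Compound 1 `CC(C)Oc1ccc(Nc2nc(=O)n(CCO)c(=O)n2Cc2ccc(Cl)cc2)cc1Cl` gives 48.1%.
Compound 2 `CC(C)Oc1ccc(/N=c2\[nH]c(=O)n(C[C@@H](O)CO)c(=O)n2Cc2ccc(Cl)cc2)cc1Cl` gives 63%.
Compound 3 `C[C@@H](Cn1c(=O)[nH]/c(=N\c2ccc(Oc3ccccn3)cc2)n(Cc2ccc(Cl)cc2)c1=O)C(=O)O` gives 52.8%.

In an ADME assay on the whole organism (Rattus norvegicus) for pharmacokinetics, using cassette dosing, at a dose of 1 mg/kg by the oral route (on this read-out lower numbers stand for lower oral bioavailability and higher numbers for higher oral bioavailability), compound 3 gives 52.8%, the second highest of the three numbers: compound 1 sits within the usual scatter of it, while compound 2 stands beyond the scatter, higher. Compound 4 `C[C@@H](Cn1c(=O)[nH]/c(=N\c2ccc(Oc3ccnc(F)c3)cc2)n(Cc2ccc(Cl)cc2)c1=O)C(=O)O` differs from compound 3 in one place: 2-fluoropyridin-4-yl in place of pyridin-2-yl on an oxygen on an aromatic ring. Among the measured compounds shown here, no pair of measured compounds shows a change of this kind, so the data give no measured size for it. A step from compound 3 to compound 4 of a number 2.8 percentage points lower from compound 3 to compound 4 (within the scatter) is expected, that is, a change not beyond the scatter in either direction. For compound 4 a value of 50% is estimated, with a range from 30% to 70%.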

Compound 4, oral bioavailability in the Rattus norvegicus assay: 43.2%
Beside the measured number, compound 4's estimate is 6.8 percentage points above it; low and high end bracket the measured number.
By their numbers in the Rattus norvegicus assay, from the lowest: compounds 4, 1 and 3 (each within the scatter of the next); then compound 2.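

In the Rattus norvegicus assay this swap on the oxygen gives a number 9.6 percentage points lower from compound 3 to compound 4 (within the scatter). In a physicochemical assay for solubility, at pH 1.2 (on this read-out lower numbers stand for lower solubility and higher numbers for higher solubility), compound 3 gives 31.5 ug/mL and compound 4 gives 2.2 ug/mL. So 2-fluoropyridin-4-yl in place of pyridin-2-yl lowers solubility at this acidic pH by far more than the scatter, while oral bioavailability stays within it: the measured solubility of compound 3, 31.5 ug/mL, and of compound 4, 2.2 ug/mL, a 14-fold lower number (1.16 log units; beyond the scatter)

The compounds shown leave open whether the fluorine alone accounts for this. They also leave open how solubility and oral bioavailability would respond if an amine or a nitrile stood on the pyridine ring instead.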